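Methyl on the phenyl: from compound 1 to compound 3

The source may hold more compounds than are shown below. What is called first, only, known or untested is meant among the compounds shown, and "the series" means these compounds.

In a functional assay on HepG2 cells (Homo sapiens) for inhibition, read by MTT assay, with a stated time of 24 h, tested at 10 uM (a lower number here means less inhibition of growth, a higher number more inhibition of growth at the concentration tested), compound 1 `CS(=O)(=O)c1ccc(-c2cnc3[nH]cc(-c4nnc(-c5ccccc5)o4)c(=O)c3c2)cc1` gives 6.98%, the lower of the two numbers in hand, though the gap to compound 2 `O=c1c(-c2nnc(-c3ccc(Cl)cc3)o2)c[nH]c2ncc(-c3ccccc3)cc12`, which in this assay gives 14.9%, lies within the scatter. Compound 3 `Cc1cccc(-c2nnc(-c3c[nH]c4ncc(-c5ccc(S(C)(=O)=O)cc5)cc4c3=O)o2)c1` differs from compound 1 by methyl in place of hydrogen on an aromatic carbon. Among the compounds with values here, no pair of measured compounds shows this change, so its size cannot be read from the numbers in hand; the expected step of a number 1 percentage points higher from compound 1 to compound 3 (within the scatter) is none beyond the scatter. Compound 3 is estimated at 8%, with a range from 0% to 22%.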

Compound 3, percent growth inhibition at one concentration: 13.3%
The estimate for compound 3 lay 5.3 percentage points below the measured number; measured number inside the range.
By their numbers in this assay, from the lowest: compounds 1, 3 and 2 (each within the scatter of the next).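

In this assay, the change from phenyl to 3-methylphenyl gives a number 6.3 percentage points higher from compound 1 to compound 3 (within the scatter), the first step read at this place on the ring. Methyl in place of hydrogen on this aromatic carbon therefore leaves the number within the scatter in this one pair. No measured evidence bears on this step. Going by these compounds, whether an amine, a carboxylic acid or a longer chain at this place would move the number beyond the scatter stays open. On these data alone, the step for the same methyl on another member of the series also stays open.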